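Working notes: cyclopropyl in place of cyclohexyl

The compounds below may be only part of what the source reports. "The series", "measured", "known", "first", "only" and "open" are said of these compounds alone.

Measured in a functional assay on MCF7 cells (Homo sapiens) for antiproliferative activity, read by MTT assay, with a stated time of 72 h; on this read-out lower numbers stand for stronger inhibition and higher numbers for weaker inhibition:
- Compound 1 `COc1ncc(-c2ccc3c(c2)NC(=O)CO3)cc1NS(=O)(=O)c1ccc(F)cc1`: 32300 nM
- Compound 2 `COc1ncc(-c2ccc3c(c2)N(C2CCCCC2)C(=O)CO3)cc1NS(=O)(=O)c1ccc(F)cc1`: 30100 nM

Compound 2 gives 30100 nM and compound 1 gives 32300 nM, values within the scatter of each other. Compound 3 `COc1ncc(-c2ccc3c(c2)N(C2CC2)C(=O)CO3)cc1NS(=O)(=O)c1ccc(F)cc1` has cyclopropyl in place of cyclohexyl on an amide-type nitrogen in a ring. Within the data shown here, the one measured step bearing on this change is a 1.1-fold lower number from compound 1 to compound 2 (0.03 log units; within the scatter), made at the same nitrogen. With that step inside the scatter, no step beyond the scatter is expected in this assay. The estimated step is a 1.0-fold lower number from compound 2 to compound 3 (0.00 log units; within the scatter). Compound 3 is estimated at 30000 nM, with an expected range of 15000 nM to 60000 nM.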

Compound 3, half-maximal inhibitory concentration: 35200 nM
For compound 3 the middle estimate is 1.2-fold (0.07 log units) below the measured one; measured number inside the range.
By their numbers in this assay, from the lowest: compounds 2, 1 and 3 (each within the scatter of the next).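

In this assay cyclopropyl in place of cyclohexyl on the amide-type nitrogen in a ring gives a 1.2-fold higher number from compound 2 to compound 3 (0.07 log units; within the scatter) and cyclopropyl in place of hydrogen gives a 1.1-fold higher number from compound 1 to compound 3 (0.04 log units; within the scatter) at the same nitrogen. Across compound 1, compound 2 and compound 3, neither the presence of a carbon ring at this nitrogen nor its size between three-membered and six-membered moves the number beyond the scatter. Nothing available explains this flat reading.

From the compounds shown here alone, whether an amine, a carboxylic acid or a longer chain on this nitrogen would move the number beyond the scatter stays open. So does whether any change elsewhere on the shared core would do so.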